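Moving the dimethylamino change onto a weaker starting point

The source may hold more compounds than are shown below. What is called first, only, known or untested is meant among the compounds shown, and "the series" means these compounds.

Of the compounds shown here, three have already been measured in an assay on Cerebral cortex for binding affinity to adenosine receptor A1 (Cavia porcellus), read by radioligand binding; on this read-out higher numbers stand for weaker inhibition and lower numbers for stronger inhibition. Compound 1 `C=CCCn1c(=O)c2[nH]cnc2n(CCC)c1=O` gives 60 nM and compound 2 `CCCn1c(=O)n(CCCN(C)C)c(=O)c2[nH]cnc21` gives 43200 nM. Compound 3 `C=CCCn1cnc2c1c(=O)n(C)c(=O)n2CCC` gives 6000 nM, which places it second highest of the three numbers: its nearest neighbour is compound 2, and compound 1 lies furthest from it.

Compound 4 `CCCn1c(=O)n(C)c(=O)c2c1ncn2CCCN(C)C` is not yet measured. It differs from compound 3 in one place: (dimethylamino)methyl in place of vinyl on a saturated chain carbon, two bonds along the chain from an aromatic nitrogen. The same change has been made once before, between compound 1 and compound 2, where it produced a 720-fold higher number from compound 1 to compound 2 (2.86 log units; beyond the scatter), an increase far beyond the scatter. Among the compounds with values here, that single step is the only direct guide, and it points to a large move in the same direction for compound 4. Because compound 3 already sits at 6000 nM, a comparably large increase would carry compound 4 into a region where the assay may no longer report a number.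

Compound 4 is therefore expected to show a large weakening, an estimated 67-fold higher number from compound 3 to compound 4 (1.82 log units; beyond the scatter). The estimated value for compound 4 is 400000 nM, with a range from 60000 nM to 3000000 nM.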

Compound 4, inhibition constant: > 200000 nM
Compound 4 ended at the assay's limit; the forecaster's own chance of this, stated with the estimate: 50%; the middle value lies beyond the limit too.
By their numbers in this assay, from the lowest: compound 1; then compound 3; then compound 2. At a limit, above all of these: compound 4.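

On a second core, this assay again responds strongly to 3-(dimethylamino)propyl in place of but-3-en-1-yl, with an at least 33-fold higher number from compound 3 to compound 4 (1.52 log units; beyond the scatter). Compound 4 stands at a limit of the assay, > 200000 nM, which is not an exact number. The large weakening is therefore no longer tied to one core, but its full size on this second core remains unknown, and the two steps can be compared only this far: the same change on two cores in this assay, a 720-fold higher number (2.86 log units; beyond the scatter) from compound 1 to compound 2 and an at least 33-fold higher number (1.52 log units; beyond the scatter) from compound 3 to compound 4; the limit leaves it open whether they differ

The compounds shown do not separate the effect of the amine nitrogen from that of the longer chain that enters with it, as both arrive in the same change. A plain pentyl chain would test the chain without any nitrogen, while a primary amine or a carboxylic acid at the end of the chain would show whether the weakening depends on the dimethylamino group itself.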